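A few compounds are considered here, and "the series" means these few. Any claim that something is new, unique, unknown or untested is made for them only; others in the source may bear on it.

Measured so far in an ADME assay on Vero cells (Chlorocebus sabaeus) for cytotoxicity, read by sulforhodamine B assay, with a stated time of 3 days; a lower number here means that less compound is tolerated, a higher number that more compound is tolerated:
compound 1 `CC1=C(C(=O)Nc2ccc(Cl)cc2)C(c2ccccc2)C(C(=O)Nc2ccc(Cl)cc2)=C(C)N1` gives 15 ug/mL;
compound 2 `COc1cc(C2C(C(=O)Nc3ccc(Cl)cc3)=C(C)NC(C)=C2C(=O)Nc2ccc(Cl)cc2)ccc1O` gives 250 ug/mL;
compound 3 `CC1=C(C(=O)Nc2ccc(Cl)cc2)C(c2ccncc2)C(C(=O)Nc2ccc(Cl)cc2)=C(C)N1` gives 78 ug/mL.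

Compound 3 stands second highest of the three numbers: compound 2 lies above it, with a 3.2-fold lower number from compound 2 to compound 3 (0.51 log units; beyond the scatter), and compound 1 lies below it, with a 5.2-fold higher number from compound 1 to compound 3 (0.72 log units; beyond the scatter). Compound 4 `CC1=C(C(=O)Nc2ccc(Cl)cc2)C(c2cccc([N+](=O)[O-])c2)C(C(=O)Nc2ccc(Cl)cc2)=C(C)N1` has not yet been measured; it differs from compound 3 by 3-nitrophenyl in place of pyridin-4-yl on a saturated ring carbon. All three measured steps change this same aryl group on the saturated ring carbon. From the bare phenyl of compound 1 both replacements raised the number, a 17-fold higher number from compound 1 to compound 2 (1.22 log units; beyond the scatter) and a 5.2-fold higher number from compound 1 to compound 3 (0.72 log units; beyond the scatter), while a 3.2-fold lower number from compound 2 to compound 3 (0.51 log units; beyond the scatter) was a modest fall. Within the data shown here, no measured compound carries a 3-nitrophenyl group, so the direction for compound 4 is uncertain, and the three aryl variants already span a wide range. Since compound 1 gives 15 ug/mL with the ring of carbon only, a return to a carbon-only ring may go with a modest decrease. Compound 4 is therefore expected at 45 ug/mL, between 13 ug/mL and 150 ug/mL. The expected step is a 1.7-fold lower number from compound 3 to compound 4 (0.24 log units; within the scatter), modest and downward.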

Compound 4, half-maximal cytotoxic concentration: 26 ug/mL
Beside the measured number, compound 4's estimate is 1.7-fold (0.24 log units) above it, within the range that was stated.
By their numbers in this assay, from the lowest: compounds 1 and 4 (each within the scatter of the next); then compound 3; then compound 2.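

In this assay, among these compounds, the 3-nitrophenyl group is the first replacement of phenyl at this saturated ring carbon that does not clearly move the number: nitro in place of hydrogen on an aromatic carbon stays within the scatter (a 1.7-fold higher number from compound 1 to compound 4 (0.24 log units; within the scatter)). The higher numbers therefore remain with the other two aryl groups, and replacing either of them with 3-nitrophenyl lowers the number, to a lesser extent from pyridin-4-yl (a 3.0-fold lower number from compound 3 to compound 4 (0.48 log units; beyond the scatter)) and to a greater extent from 4-hydroxy-3-methoxyphenyl (a 9.6-fold lower number from compound 2 to compound 4 (0.98 log units; beyond the scatter)). Nothing available here explains these differences.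

The compounds shown do not separate the hydroxy group from the methoxy group in the high number of compound 2. They also leave open how an amine or a carboxylic acid on this aryl ring would change the number.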